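Free acid from a triazolylmethyl ester of a sesterterpenoid

A few compounds are considered here, and "the series" means these few. Any claim that something is new, unique, unknown or untested is made for them only; others in the source may bear on it.

Compound 1 `C/C(=C\CC/C(C)=C/CC[C@@H]1[C@@]2(C)CCC(=O)C(C)(C)[C@H]2CC[C@@]1(C)O)CC/C=C(\C)C(=O)OCc1cn(-c2ccc(C(F)(F)F)cc2)nn1` gives a limit of the assay in a functional assay on MDA-MB-231 cells (Homo sapiens) for antiproliferative activity, read by MTT assay, with a stated time of 48 h; on this read-out higher numbers stand for weaker inhibition and lower numbers for stronger inhibition: > 150000 nM.
Compound 2 `C#CCOC(=O)/C(C)=C/CC/C(C)=C/CC/C(C)=C/CC[C@@H]1[C@@]2(C)CCC(=O)C(C)(C)[C@H]2CC[C@@]1(C)O` gives 114000 nM in this assay.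
Compound 3 `C/C(=C\CC/C(C)=C/CC[C@@H]1[C@@]2(C)CCC(=O)C(C)(C)[C@H]2CC[C@@]1(C)O)CC/C=C(\C)C(=O)OCc1cn(-c2ccccc2)nn1` gives a limit of the assay in this assay: > 150000 nM.

Compound 3 stands at a limit of the assay, and so does compound 1; only compound 2 gives a number, and the step of an at least 1.3-fold higher number from compound 2 to compound 3 (0.11 log units; that floor lies within the scatter) has a floor that lies within the scatter. The step that the two limits leave unreadable from compound 1 to compound 3 cannot be read because both values sit at the limit of > 150000 nM in this assay, at which 2 of the 3 values shown sit.

Compound 4 `C/C(=C\CC/C(C)=C/CC[C@@H]1[C@@]2(C)CCC(=O)C(C)(C)[C@H]2CC[C@@]1(C)O)CC/C=C(\C)C(=O)O` differs from compound 3 in one place: hydrogen in place of (1-phenyl-1H-1,2,3-triazol-4-yl)methyl on an oxygen next to a carbonyl group. Among the measured compounds shown here, no measured step removes the whole ester group, so the account rests on the fact that all three esters sit at or near the limit. Compound 4 is therefore expected to remain near that limit, with a step that the limit leaves unreadable from compound 3 to compound 4 as the step expected from compound 3. Compound 4 is estimated at 160000 nM, within 60000 nM to 400000 nM, and a limit rather than a number is the likelier outcome.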

Compound 4, half-maximal inhibitory concentration: 90500 nM
The estimate for compound 4 lay 1.8-fold (0.25 log units) above the measured number, and the stated range covers the measured number.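

Compound 4 carries a free carboxylic acid where the other compounds carry esters, and in this assay replacing the (1-phenyl-1H-1,2,3-triazol-4-yl)methyl group with hydrogen gives an at least 1.6-fold lower number from compound 3 to compound 4 (0.21 log units; that floor lies within the scatter). Replacing propargyl with hydrogen on the same oxygen gives a 1.3-fold lower number from compound 2 to compound 4 (0.10 log units; within the scatter), so the free acid and the propargyl ester cannot be told apart here. The triazolylmethyl esters, compound 1 and compound 3, stay at a limit of the assay, whereas compound 4 gives a number: the limit of > 150000 nM in this assay, at which 2 of the 4 values shown sit.

On these data alone, it remains open whether a small methyl ester or a primary amide at this position would give a value clearly apart from that of compound 4. As far as these compounds go, it is equally open whether an amine in place of the carbonyl on the shared core would move these values at all.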